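From 2-fluorophenyl to 2-chlorophenyl: a small expected step

The source may hold more compounds than are shown below. What is called first, only, known or untested is meant among the compounds shown, and "the series" means these compounds.

Of the compounds shown here, three sharing one core have been measured so far in a functional assay on MIA PaCa-2 cells (Homo sapiens) for inhibition, read by MTT assay, with a stated time of 48 h, tested at 10 uM (on this read-out higher numbers stand for more inhibition of growth at the one concentration tested and lower numbers for less inhibition of growth), and serve as the basis here. Compound 1 (`CN1CC[C@H](c2c(O)cc(O)c3c(=O)cc(/C=C/c4ccccc4)oc23)[C@H](O)C1`) carries a plain phenyl and gives 87% on this measure. Compound 2 (`CN1CC[C@H](c2c(O)cc(O)c3c(=O)cc(/C=C/c4c(F)c(F)c(F)c(F)c4F)oc23)[C@H](O)C1`) carries 2,3,4,5,6-pentafluorophenyl and gives 89% on the same measure. Compound 3 (`CN1CC[C@H](c2c(O)cc(O)c3c(=O)cc(/C=C/c4ccccc4F)oc23)[C@H](O)C1`) carries 2-fluorophenyl and gives 60% as the lowest of the three numbers.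

Compound 4 (`CN1CC[C@H](c2c(O)cc(O)c3c(=O)cc(/C=C/c4ccccc4Cl)oc23)[C@H](O)C1`) is compound 3 with chloro in place of fluoro on an aromatic carbon. Among the measured compounds shown here, no measured compound carries chloro, so no step speaks to this swap directly. For the measured compounds named here, three steps bear on it only indirectly. The single fluoro came with a number 27 percentage points lower from compound 1 to compound 3 (beyond the scatter) as one modest move, and the swap from the pentafluorinated ring came with a number 29 percentage points lower from compound 2 to compound 3 (beyond the scatter) as another. Compound 2 goes against any simple fluorine trend, with a number 2 percentage points higher from compound 1 to compound 2 (within the scatter) as its step. These steps show that changes on this ring can move the number, but not how chloro compares with fluoro. The estimated change is a number 6 percentage points higher from compound 3 to compound 4 (within the scatter) and so stays small, with wide uncertainty. Compound 4 is expected at about 66% with an estimated range from 48% to 85% in this assay when it is tested.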

Compound 4, percent growth inhibition at one concentration: 59%
The estimate for compound 4 lay 7 percentage points above the measured number, and the stated range covers the measured number.
By their numbers in this assay, from the lowest: compounds 4 and 3 (each within the scatter of the next); then compounds 1 and 2 (each within the scatter of the next).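

In this assay, chloro in place of fluoro on an aromatic carbon, ortho to a large group, comes with a number 1 percentage points lower from compound 3 to compound 4 (within the scatter), so this read-out does not separate these two halogens at this place. Measured against the plain phenyl, the same chloro comes with a number 28 percentage points lower from compound 1 to compound 4 (beyond the scatter), and the 2-chlorophenyl in place of the 2,3,4,5,6-pentafluorophenyl comes with a number 30 percentage points lower from compound 2 to compound 4 (beyond the scatter), so compound 3 and compound 4 now form a matching pair apart from compound 1 and compound 2, although compound 2 goes against any rule that a halogen at this place lowers the number: it also carries fluoro there, and its step is a number 2 percentage points higher from compound 1 to compound 2 (within the scatter). Nothing measured here explains why the two single halogens match or why the pentafluorinated ring departs from them.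

Still open, going by these compounds, is whether a bromo, a methyl or a methoxy at this same place would read like compound 3 and compound 4 or like compound 1, and whether a single chloro elsewhere on the ring would give the same picture. How an amine or a carboxylic acid on this ring would read is also an open question, as is how these compounds would separate across a range of concentrations.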